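Halophenyl swap in a series at the assay limit

A few compounds are considered here, and "the series" means these few. Any claim that something is new, unique, unknown or untested is made for them only; others in the source may bear on it.

Measured in a functional assay on HCT-116 cells (Homo sapiens) for inhibition, read by MTT assay, with a stated time of 2 days (on this read-out higher numbers stand for lower toxicity in this test and lower numbers for higher toxicity in this test), with every entry a limit of the assay and not a number:
- Compound 1 `Nc1ccccc1NC(=O)CCCNCC(=O)Nc1ccc(Cl)cc1` gives > 100000 nM as a limit
- Compound 2 `Nc1ccccc1NC(=O)CCCNCC(=O)Nc1ccc(Br)cc1` gives > 100000 nM as a limit
- Compound 3 `Nc1ccccc1NC(=O)c1ccc(NCC(=O)Nc2cccc([N+](=O)[O-])c2)cc1` gives > 100000 nM as a limit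

Compound 2 stands at > 100000 nM as a limit, so it has no numerical place in the series. The next step leads to compound 4 `Nc1ccccc1NC(=O)CCCNCC(=O)Nc1ccccc1Cl` and brings 2-chlorophenyl in place of 4-bromophenyl on an amide-type nitrogen with the rest of the structure unchanged.

Within the data shown here, the only measured step bearing on this change is a step that the two limits leave unreadable from compound 1 to compound 2 with bromo in place of chloro on an aromatic carbon, and it offers no size to carry forward. The wider guide is the limit of > 100000 nM in this assay, at which 3 of the 3 values shown sit, and it gives no measured response to a change of the halophenyl group. No step beyond the scatter is therefore expected in this assay and no direction can be assigned. The expected step is a number no higher from compound 2 to compound 4 (the limit leaves the size open) and this remains an estimate resting on the shared limit. For compound 4 the estimate is 100000 nM with an expected range from 50000 nM to 200000 nM and another limit is the most likely report.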

Compound 4, concentration lethal to 50% of the cells: > 100000 nM
Compound 4 was reported as a limit; the forecaster's own chance of this, stated with the estimate: 80%; the middle value sits exactly at the limit.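

In this assay compound 4 gives > 100000 nM, a limit of the assay. The steps to compound 4 from compound 1 and from compound 2 cannot be read, so the series yields no new step: the limit of > 100000 nM in this assay, at which 4 of the 4 values shown sit.

The compounds shown leave open whether any change of the halophenyl group has a measurable size in this assay.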